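The source may report more compounds than this note shows. Statements on the series, on what has been measured and on what is new or still open speak of the compounds shown alone.

In a functional assay on SiHa cells (Homo sapiens) for inhibition, read by sulforhodamine B assay (a lower number here means a stronger inhibitor of growth, a higher number a weaker inhibitor of growth), compound 1, `Oc1cccc2[nH]c(-c3ccc(-c4ccc(-c5ccc(OC(F)(F)F)cc5)cc4)cc3)nc12`, gives 8410 nM. Among the compounds with values here, only one other measured compound stands beside it: compound 2, `Oc1cccc2[nH]c(-c3ccc(-c4ccc(-c5cccc(Cl)c5)cc4)cc3)nc12`, gives 8400 nM. The two are level, with a step of a 1.0-fold lower number from compound 1 to compound 2 (0.00 log units; within the scatter), and that step puts 3-chlorophenyl in place of 4-(trifluoromethoxy)phenyl. Compound 3, `Cc1ccc2[nH]c(-c3ccc(-c4ccc(-c5ccc(OC(F)(F)F)cc5)cc4)cc3)nc2c1`, keeps the 4-(trifluoromethoxy)phenyl of compound 1 and changes a different place: 5-methyl-1H-benzimidazol-2-yl in place of 4-hydroxy-1H-benzimidazol-2-yl on an aromatic carbon. In short, 5-methyl-1H-benzimidazol-2-yl replaces 4-hydroxy-1H-benzimidazol-2-yl. Within the data shown here, no measured step tests this exchange, so the evidence is thin. Among the measured compounds shown here, the one step available, a 1.0-fold lower number from compound 1 to compound 2 (0.00 log units; within the scatter), concerns another group and shows no movement beyond the scatter, so no clear direction can be expected here. The expected change is small, an estimated 1.1-fold lower number from compound 1 to compound 3 (0.02 log units; within the scatter). For compound 3 the estimated value is 8000 nM, within an expected range from 2500 nM to 25000 nM.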

Compound 3, concentration for 50% growth inhibition: 28300 nM
Compound 3: middle estimate off by 3.5-fold (0.55 log units), on the low side; measured number above the stated range.
By their numbers in this assay, from the lowest: compounds 2 and 1 (each within the scatter of the next); then compound 3.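

In this assay, within the data shown here, replacing 4-hydroxy-1H-benzimidazol-2-yl with 5-methyl-1H-benzimidazol-2-yl gives a 3.4-fold higher number from compound 1 to compound 3 (0.53 log units; beyond the scatter), a modest weakening of growth inhibition and the first change in this set to move beyond the scatter. The earlier exchange of 4-(trifluoromethoxy)phenyl for 3-chlorophenyl showed no such movement, so this part of the molecule can affect the read-out even though the other exchange did not. No available measurement explains the weakening.

This single exchange removes a hydroxy group, adds a methyl group and changes where the substituent sits, so the effects of these differences remain unseparated. On these data alone, an unsubstituted 1H-benzimidazol-2-yl group, or a 4-methoxy-1H-benzimidazol-2-yl group, would help to show which difference matters, and whether the same step appears alongside 3-chlorophenyl also remains open.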